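A Benzoxazole Replacing the Carboxyphenyl Group

A few compounds are considered here, and "the series" means these few. Any claim that something is new, unique, unknown or untested is made for them only; others in the source may bear on it.

Compound 1 `CCN(CC)c1nc(Nc2cccc(C(=O)O)c2)nc(OC(C(F)(F)F)C(F)(F)F)n1` was tested in an assay on cells for activation of Cystic fibrosis transmembrane conductance regulator (Homo sapiens), read by fluorescence, with stated times of 10 min and 12 s (on this read-out higher numbers stand for an effect only at larger amounts of compound and lower numbers for an effect already at smaller amounts), and gives 160 nM; among the three measured compounds its number is the second highest. Compound 2 `CCN(CC)c1nc(Nc2cccc(F)c2)nc(OC(C(F)(F)F)C(F)(F)F)n1` gives 140 nM, and the step of a 1.1-fold lower number from compound 1 to compound 2 (0.06 log units; within the scatter). Compound 3 `CCN(CC)c1nc(Nc2ccc3[nH]ncc3c2)nc(OC(C(F)(F)F)C(F)(F)F)n1` gives 2800 nM; the steps of an 18-fold higher number from compound 1 to compound 3 (1.24 log units; beyond the scatter) and a 20-fold higher number from compound 2 to compound 3 (1.30 log units; beyond the scatter). Compound 4 `CCN(CC)c1nc(Nc2ccc3ncoc3c2)nc(OC(C(F)(F)F)C(F)(F)F)n1` carries the change (1,3-benzoxazol-6-yl in place of 3-carboxyphenyl on a nitrogen on an aromatic ring). The two large steps toward compound 3 are the ones that bear on this change, since each also brought a fused heteroaromatic group onto that nitrogen in place of a single phenyl ring, so a step upward of roughly comparable size is expected for compound 4, namely a 9.4-fold higher number from compound 1 to compound 4 (0.97 log units; beyond the scatter). In this assay compound 4 is therefore estimated at 1500 nM, within a range from 500 nM to 5000 nM.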

Compound 4, half-maximal effective concentration: 150 nM
Compound 4: middle estimate off by 10-fold (1.00 log units), on the high side; measured number outside the range, below it.
By their numbers in this assay, from the lowest: compounds 2, 4 and 1 (each within the scatter of the next); then compound 3.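

In this assay the 1,3-benzoxazol-6-yl group on this nitrogen stands level with the 3-carboxyphenyl group (a 1.1-fold lower number from compound 1 to compound 4 (0.03 log units; within the scatter)) and with the 3-fluorophenyl group (a 1.1-fold higher number from compound 2 to compound 4 (0.03 log units; within the scatter)), so a fused group at this place does not by itself bring a higher number. The two fused groups differ widely (a 19-fold lower number from compound 3 to compound 4 (1.27 log units; beyond the scatter)), which ties the high number of compound 3 to the 1H-indazol-5-yl group rather than to fusion as such. No evidence at hand explains this difference. Still open, as far as these compounds go, is whether a 1,3-benzothiazol-6-yl group would stay level with compound 4, and whether an amine on the benzoxazole would change the number.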